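A Pyridinyl Replaces the Thiazolyl on the Biaryl Tail

This account rests on a few compounds, and the source may have more. Where it says the series, first, only, none or still open, it means among the compounds named here.

Of the compounds shown here, three built on one shared core have been measured in a functional assay on HEK293 cells for agonist activity at Bombesin receptor subtype-3 (Mus musculus), read by luminescence and calcium flux, with a stated time of 10 min; a lower number here means that less compound is needed, a higher number that more compound is needed for the effect. Compound 1 `CCC(C)(C)Cc1c[nH]c(CCc2ccc(-c3ccncc3)cc2)n1` gives 15 nM. Compound 2 `CCC(C)(C)Cc1c[nH]c(CCc2ccc(-c3cccc(N)n3)cc2)n1` gives 3.9 nM, and compound 3 `CCC(C)(C)Cc1c[nH]c(CCc2ccc(-c3cnsc3)cc2)n1` gives 6.9 nM. Among these three numbers compound 3 stands second highest: its nearest neighbour is compound 2, and the two lie within the scatter of each other, while compound 1 is the furthest away, a 2.2-fold lower number from compound 1 to compound 3 (0.34 log units; beyond the scatter).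

Compound 4 `CCC(C)(C)Cc1c[nH]c(CCc2ccc(-c3cccnc3)cc2)n1` has not yet been measured. It differs from compound 3 by pyridin-3-yl in place of 1,2-thiazol-4-yl on an aromatic carbon. The step already mentioned from compound 1 to compound 3 is the one that bears most on this change, since it replaced a six-membered ring with one nitrogen by the five-membered ring; compound 4 returns to a six-membered ring with one nitrogen, though a different pyridinyl from that in compound 1, so that step gives only a rough guide. The step of a 3.8-fold lower number from compound 1 to compound 2 (0.59 log units; beyond the scatter) shows how much exchanging one such ring for another can move the number. A modest rise, or none beyond the scatter, is therefore expected, and the expected step is a 1.4-fold higher number from compound 3 to compound 4 (0.16 log units; within the scatter). Compound 4 is estimated at 10 nM, with a range from 4 nM to 25 nM.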

Compound 4, half-maximal effective concentration: 4.3 nM
Compound 4: the middle estimate sits 2.3-fold (0.37 log units) above what was measured; the range from low to high includes it.
By their numbers in this assay, from the lowest: compounds 2, 4 and 3 (each within the scatter of the next); then compound 1.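

In this assay, this position distinguishes between two pyridinyl groups that differ only in where the ring is joined: with pyridin-3-yl in place of pyridin-4-yl, there is a 3.5-fold lower number from compound 1 to compound 4 (0.54 log units; beyond the scatter), a modest step beyond the scatter. The result also shows that a six-membered ring with one nitrogen need not differ from the five-membered 1,2-thiazol-4-yl, as a 1.6-fold lower number from compound 3 to compound 4 (0.21 log units; within the scatter) lies within the scatter, and that the amine-bearing 6-aminopyridin-2-yl cannot be separated from plain pyridin-3-yl, as a 1.1-fold higher number from compound 2 to compound 4 (0.04 log units; within the scatter) also lies within the scatter. Ring size alone therefore does not sort these compounds, since compound 1 stands apart from compounds 2, 3 and 4 while sharing its ring size with compounds 2 and 4.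

No measured evidence here explains why pyridin-4-yl stands apart from the other three groups. Also open, from the compounds shown here alone, is whether pyridin-2-yl without its amine, or an amine or a carboxylic acid added to the pyridin-3-yl ring, would move the number beyond the scatter.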